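A propyl amide becomes an aryl amide: cytotoxicity expectations

The source may report more compounds than this note shows. Statements on the series, on what has been measured and on what is new or still open speak of the compounds shown alone.

Compound 1 `C=CC1=C(C(=O)NCCC)C(c2ccc(F)cc2)OC1` in a functional assay on SW480 cells (Homo sapiens) for cytotoxicity, read by MTT assay, with a stated time of 24 h; on this read-out higher numbers stand for weaker inhibition and lower numbers for stronger inhibition: > 100000 nM, a limit of the assay.
Compound 2 `C=CC1=C(C(=O)NC(C)(C)C)C(c2ccc(Cl)c(Cl)c2)OC1` in this assay: > 100000 nM, a limit.
Compound 3 `C=CC1=C(C(=O)Nc2ccccc2OC)C(c2ccc(Cl)c(Cl)c2)OC1` in this assay: > 100000 nM, a limit.

Compound 1 therefore stands at a limit, as do the other two; none of the three can be ranked. Among the measured compounds shown here, the only measured step that alters the group on the amide-type nitrogen, a step that the two limits leave unreadable from compound 2 to compound 3, cannot be sized because the limit of > 100000 nM in this assay, at which 3 of the 3 values shown sit, holds at both of its ends. Compound 4 `C=CC1=C(C(=O)Nc2ccc(C)cc2)C(c2ccc(F)cc2)OC1` differs from compound 1 by 4-methylphenyl in place of propyl on an amide-type nitrogen. No readable step bears on this change, so nothing beyond the scatter can be foreseen in this assay, and compound 4 is most likely expected to return only a limit again. The estimate for compound 4 is 200000 nM, ranging from 50000 nM to 1000000 nM, and the expected step is a step that the limit leaves unreadable from compound 1 to compound 4.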

Compound 4, half-maximal inhibitory concentration: > 100000 nM
Compound 4 gave a limit, no number; the forecaster's own chance of this, stated with the estimate: 85%; the middle value is on the limit's open side.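

No step can be read from compound 1 to compound 4, because both values are limits rather than numbers: the limit of > 100000 nM in this assay, at which 4 of the 4 values shown sit. The compounds shown leave open whether changing the group on the amide-type nitrogen alters the result in this assay.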